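Swapping Methoxy for Nitro on an Inactive Isoxazole Amide

A few compounds are considered here, and "the series" means these few. Any claim that something is new, unique, unknown or untested is made for them only; others in the source may bear on it.

Compound 1 `COc1ccc(-c2cn(CC(=O)Nc3nccs3)nn2)cc1` gives 510 nM in a functional assay on BMDM cells (Mus musculus, strain C57BL/6) for inhibition, with a stated time of 2 days; a higher number here means a weaker inhibitor, a lower number a stronger inhibitor. Compound 2 `COc1ccc(-c2cn(CC(=O)Nc3cc(C)on3)nn2)cc1` differs from it only in the group on the amide-type nitrogen. In this assay compound 2 reaches only > 30000 nM, which is a limit of the measurement rather than a number. The step of an at least 58-fold higher number from compound 1 to compound 2 (1.76 log units; beyond the scatter) is therefore a large loss, and compound 2 sits at the weak end of the two values shown, at the limit of > 30000 nM in this assay, at which 1 of the 2 values shown sits. Compound 3 `Cc1cc(NC(=O)Cn2cc(-c3ccc([N+](=O)[O-])cc3)nn2)no1` keeps the amide and rings of compound 2 and differs in one spot: nitro in place of methoxy on an aromatic carbon. Among the compounds with values here, no measured step touches this part of the structure; the one known step concerns the group on the amide-type nitrogen, not the ring that carries the methoxy. With compound 2 already at the limit, compound 3 is expected to show no step beyond the scatter a step that the limit leaves unreadable from compound 2 to compound 3, most likely again as a limit. The estimate for compound 3 is 40000 nM, with a range from 10000 nM to 150000 nM.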

Compound 3, half-maximal inhibitory concentration: 1220 nM
Estimate against measurement, compound 3: 33-fold (1.52 log units) above, and the stated range ends above it.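

Within the data shown here, the aromatic carbon para to a large group, which no earlier step had touched, turns out to matter greatly in this assay: nitro in place of methoxy gives an at least 24-fold lower number from compound 2 to compound 3 (1.39 log units; beyond the scatter). The 5-methyl-1,2-oxazol-3-yl group therefore does not rule out activity on its own, since compound 3 carries it and gives 1220 nM. Compound 2 provides only a limit, so this step is a bound and not an exact size: the limit of > 30000 nM in this assay, at which 1 of the 3 values shown sits.

Going by these compounds, whether nitro in place of methoxy would shift compound 1, which has 1,3-thiazol-2-yl on the amide-type nitrogen, in the same way remains open. Also open, on these data alone, is whether an amine, a nitrile or a carboxylic acid on this aromatic carbon would behave more like nitro or more like methoxy.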